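From 4-aminopyridin-3-yl to 6-aminopyridin-3-yl: a flat series so far

The source may report more compounds than this note shows. Statements on the series, on what has been measured and on what is new or still open speak of the compounds shown alone.

Of the compounds shown here, three sharing one core have been measured in a functional assay on SGC-7901 cells (Homo sapiens) for cytotoxicity, read by MTT assay, with a stated time of 48 h; on this read-out lower numbers stand for stronger inhibition and higher numbers for weaker inhibition. Compound 1 `Cc1ncc([N+](=O)[O-])n1CCSc1nnc(-c2ccccc2N)o1` gives 35100 nM, compound 2 `Cc1ncc([N+](=O)[O-])n1CCSc1nnc(-c2ccccc2O)o1` gives 30500 nM, and compound 3 `Cc1ncc([N+](=O)[O-])n1CCSc1nnc(-c2cnccc2N)o1` gives 34500 nM. Compound 3 therefore stands level with both of the others, within the scatter.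

Compound 4 `Cc1ncc([N+](=O)[O-])n1CCSc1nnc(-c2ccc(N)nc2)o1` has the same atoms as compound 3, joined differently: 6-aminopyridin-3-yl in place of 4-aminopyridin-3-yl on an aromatic carbon. The exchange falls on the aromatic carbon of the five-membered aromatic ring with 2 nitrogen and 1 oxygen. The measured exchanges at this same place are small: a 1.0-fold lower number from compound 1 to compound 3 (0.01 log units; within the scatter), a 1.2-fold lower number from compound 1 to compound 2 (0.06 log units; within the scatter) and a 1.1-fold higher number from compound 2 to compound 3 (0.05 log units; within the scatter), each within the scatter. None of them is this exact change, so the evidence is only indirect. On that evidence, no shift beyond the scatter is expected in this assay. The expected step is a 1.0-fold lower number from compound 3 to compound 4 (0.02 log units; within the scatter). For compound 4 the estimated value is 33000 nM, with an expected range from 16000 nM to 65000 nM.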

Compound 4, half-maximal inhibitory concentration: 30900 nM
Beside the measured number, compound 4's estimate is 1.1-fold (0.03 log units) above it; the range from low to high includes it.
By their numbers in this assay, from the lowest: compounds 2, 4, 3 and 1 (each within the scatter of the next).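

Within the data shown here, compound 3 and compound 4 hold the same atoms joined differently, so this is the first exchange that only rearranges the group at this position: with 6-aminopyridin-3-yl in place of 4-aminopyridin-3-yl, this assay shows a 1.1-fold lower number from compound 3 to compound 4 (0.05 log units; within the scatter). The new group also stands level with 2-hydroxyphenyl and 2-aminophenyl, with a 1.0-fold higher number from compound 2 to compound 4 (0.01 log units; within the scatter) and a 1.1-fold lower number from compound 1 to compound 4 (0.06 log units; within the scatter), so this read-out does not separate any of the four groups at this position. Nothing available bears on why the series is so flat.

From the compounds shown here alone, all four compounds carry a six-membered aromatic ring at this position, so the effect of a carboxylic acid on that ring, or of an open alkyl chain in its place, remains open. Also open, going by these compounds, is whether a longer chain in the sulfur-bearing link of the shared core would move the number.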